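Will Methylating the Hydroxy Group Shift Compound 3?

This account rests on a few compounds, and the source may have more. Where it says the series, first, only, none or still open, it means among the compounds named here.

Measured so far in a functional assay on A549 cells (Homo sapiens) for inhibition, read by MTT assay, with a stated time of 48 h; on this read-out lower numbers stand for stronger inhibition and higher numbers for weaker inhibition:
compound 1 `c1ccc(C(c2c[nH]c3ccccc23)c2c[nH]c3ccccc23)cc1`: 40000 nM
compound 2 `Brc1ccc2[nH]cc(C(c3ccccc3)c3c[nH]c4ccc(Br)cc34)c2c1`: 7500 nM
compound 3 `Oc1ccc(C(c2c[nH]c3ccc(Br)cc23)c2c[nH]c3ccc(Br)cc23)cc1`: 9000 nM

Among these three numbers, compound 3 sits level with compound 2 within the usual scatter, and both lie well under compound 1, so both show stronger inhibition. The next molecule is compound 4 (`COc1ccc(C(c2c[nH]c3ccc(Br)cc23)c2c[nH]c3ccc(Br)cc23)cc1`), which differs from compound 3 in a single place: methyl in place of hydrogen on an oxygen on an aromatic ring. The hydroxy thus becomes a methoxy, and the 4-hydroxyphenyl becomes a 4-methoxyphenyl.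

For the measured compounds named here, only one measured step touches this part of the molecule. It is the arrival of the hydroxy itself, a 1.2-fold higher number from compound 2 to compound 3 (0.08 log units; within the scatter), and it stays within the scatter. That step does not test a methyl on the oxygen, so the data offer no direct case and give no reason to favour either direction. A small change at this spot has so far left the number in this assay essentially unmoved, so no shift beyond the scatter is expected here. The estimated step is a 1.1-fold lower number from compound 3 to compound 4 (0.02 log units; within the scatter), which is no real change. The estimate for compound 4 is 8500 nM, with an expected range from 4000 nM to 20000 nM.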

Compound 4, half-maximal inhibitory concentration: 10000 nM
Beside the measured number, compound 4's estimate is 1.2-fold (0.07 log units) below it; the range from low to high includes it.
By their numbers in this assay, from the lowest: compounds 2, 3 and 4 (each within the scatter of the next); then compound 1.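

In this assay, putting a methyl on the oxygen turns the hydroxy into a methoxy and gives a 1.1-fold higher number from compound 3 to compound 4 (0.05 log units; within the scatter), so this first direct test of the change leaves the number level with that of the free hydroxy. The methoxy also stands level with plain hydrogen on the aromatic carbon, with a 1.3-fold higher number from compound 2 to compound 4 (0.12 log units; within the scatter), which means that hydrogen, hydroxy and methoxy at this place cannot be told apart in this assay, whether or not a hydrogen sits on the oxygen. Nothing available explains why these three compounds read alike.

Going by these compounds, what stays open is whether a group of another kind at this place, such as an amine, a carboxylic acid or a longer chain on the oxygen, would move the number beyond the scatter. All of these comparisons also rest on the bromine-bearing core of compound 3, so it remains unanswered whether the methoxy would behave the same way on the core of compound 1, which carries no bromine.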